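The compounds below may be only part of what the source reports. "The series", "measured", "known", "first", "only" and "open" are said of these compounds alone.

Compound 3 `C[C@H]1[C@@H](N)CN1c1c(F)cc2c(=O)c(C(=O)O)cn(C3CC3)c2c1F` sits at the low end of the three solubility numbers gathered so far. In a physicochemical assay for solubility, at pH 7.4 (on this read-out lower numbers stand for lower solubility and higher numbers for higher solubility), compound 3 gives 23.6 ug/mL, level with compound 1 `CN(C)C1(C)CN(c2c(F)cc3c(=O)c(C(=O)O)cn(C4CC4)c3c2F)C1`, which gives 23.6 ug/mL. For the measured compounds named here, compound 2 `C[C@@H]1[C@@H](N(C)C)CN1c1cc2c(cc1F)c(=O)c(C(=O)O)cn2C1CC1`, whose core carries a different fluorine pattern, gives 96.3 ug/mL in this assay; no single-point step links it to compound 3, so its value stands on its own. The change to compound 4 `C[C@@H]1[C@@H](N(C)C)CN1c1c(F)cc2c(=O)c(C(=O)O)cn(C3CC3)c2c1F` is a group of 8 heavy atoms (6 carbon, 2 nitrogen; one four-membered non-aromatic ring with 1 hetero atom) in place of a group of 6 heavy atoms (4 carbon, 2 nitrogen; one four-membered non-aromatic ring with 1 hetero atom), on an aromatic carbon. Going by the values given here, the one measured step that bears on this is the one from compound 1 to compound 3, which is no change at the digits printed from compound 1 to compound 3 (within the scatter); it exchanges the two azetidine groups in the opposite sense and leaves the number where it was. Compound 4 is therefore expected to show a 1.1-fold higher number from compound 3 to compound 4 (0.03 log units; within the scatter), a step of no change beyond the scatter. The estimate for compound 4 in this assay is 25 ug/mL, with a range from 10 ug/mL to 60 ug/mL.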

Compound 4, solubility: 97.1 ug/mL
The estimate for compound 4 lay 3.9-fold (0.59 log units) below the measured number; measured number above the stated range.
By their numbers in this assay, from the lowest: compounds 1 and 3 (each within the scatter of the next); then compounds 2 and 4 (each within the scatter of the next).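

In this assay, for the compounds shown here, the group of 8 heavy atoms in place of the group of 6 heavy atoms on this aromatic carbon gives a 4.1-fold higher number from compound 3 to compound 4 (0.61 log units; beyond the scatter), the first step at this position to lie beyond the scatter. The heavy-atom count of the group does not decide the reading, since compound 1 and compound 4 share the same core and the same count yet show a 4.1-fold higher number from compound 1 to compound 4 (0.61 log units; beyond the scatter), so the arrangement of atoms within the group matters for these compounds. Fluoro in place of hydrogen on an aromatic carbon gives a 1.0-fold higher number from compound 2 to compound 4 (0.00 log units; within the scatter), so this pair shows no effect of that change.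

Nothing at hand accounts for the difference between these groups. The compounds shown leave open whether a piperazine or a pyrrolidine ring on this aromatic carbon would read like compound 3 or like compound 4.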